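The source may hold more compounds than are shown below. What is called first, only, known or untested is meant among the compounds shown, and "the series" means these compounds.

Four compounds share one core and differ in two places: the group on the oxygen of the chloro-substituted ring and the trifluoromethyl count on the outer ring of the urea. Compound 1 `O=C(Nc1cccc(-n2cc(-c3ccncc3)c(-c3ccc(Cl)c(O)c3)n2)c1)Nc1cccc(C(F)(F)F)c1`, compound 2 `COc1cc(-c2nn(-c3cccc(NC(=O)Nc4cc(C(F)(F)F)cc(C(F)(F)F)c4)c3)cc2-c2ccncc2)ccc1Cl` and compound 3 `COc1cc(-c2nn(-c3cccc(NC(=O)Nc4cccc(C(F)(F)F)c4)c3)cc2-c2ccncc2)ccc1Cl` have been tested in a functional assay on 786-0 cells (Homo sapiens) for inhibition, read by sulforhodamine B assay, with a stated time of 48 h; on this read-out lower numbers stand for stronger inhibition of growth and higher numbers for weaker inhibition of growth. In this assay compound 1 gives > 32500 nM, which is a limit of the assay and not a number. Compound 3 gives 4050 nM. Compound 2 gives 2020 nM, the lower of the two numbers, yet the gap to compound 3, a 2.0-fold higher number from compound 2 to compound 3 (0.30 log units; within the scatter), is within the scatter, so the two cannot be ordered. The step from the oxygen bearing hydrogen to the oxygen bearing methyl, an at least 8.0-fold lower number from compound 1 to compound 3 (0.90 log units; beyond the scatter), is the one step shown that goes beyond the scatter.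

Compound 4 `O=C(Nc1cccc(-n2cc(-c3ccncc3)c(-c3ccc(Cl)c(O)c3)n2)c1)Nc1cc(C(F)(F)F)cc(C(F)(F)F)c1` is not yet measured. It differs from compound 2 by hydrogen in place of methyl on an oxygen on an aromatic ring. This is the reverse of the change between compound 1 and compound 3, so a step of at least that size toward a higher number is expected, with a fair chance that the assay again reports only (the limit of > 32500 nM in this assay, at which 1 of the 3 values shown sits). Compound 4 is therefore expected to give about 30000 nM, somewhere between 12000 nM and 80000 nM. The expected step is a 15-fold higher number from compound 2 to compound 4 (1.17 log units; beyond the scatter).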

Compound 4, concentration for total growth inhibition: 3160 nM
The estimate for compound 4 lay 9.5-fold (0.98 log units) above the measured number; measured number below the stated range.
By their numbers in this assay, from the lowest: compounds 2, 4 and 3 (each within the scatter of the next). At a limit, above all of these: compound 1.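

In this assay, going from 4-chloro-3-methoxyphenyl to 4-chloro-3-hydroxyphenyl gives a 1.6-fold higher number from compound 2 to compound 4 (0.19 log units; within the scatter), so hydroxy at this position does not lose growth inhibition when the outer ring carries two trifluoromethyl groups. The effect of this change therefore depends on the rest of the molecule, which compounds 1 and 3 alone could not show: the same change on two cores in this assay, an at least 8.0-fold lower number (0.90 log units; beyond the scatter) from compound 1 to compound 3 and a 1.6-fold lower number (0.19 log units; within the scatter) from compound 4 to compound 2, at least 5.1-fold (0.71 log units) apart, beyond the scatter of two such steps. Going by these compounds alone, the second trifluoromethyl group gives an at least 10-fold lower number from compound 1 to compound 4 (1.01 log units; beyond the scatter), a step that rests on a limit of the assay for compound 1 and has no counterpart among the methoxy compounds: the same change on two cores in this assay, a 2.0-fold higher number (0.30 log units; within the scatter) from compound 2 to compound 3 and an at least 10-fold higher number (1.01 log units; beyond the scatter) from compound 4 to compound 1, at least 5.1-fold (0.71 log units) apart, beyond the scatter of two such steps.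

The compounds shown carry only hydrogen or methyl on this oxygen, so it remains open how a longer chain such as ethyl, or an amine in place of the oxygen, would fare. They also cannot tell why the two changes depend on each other.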